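The source may report more compounds than this note shows. Statements on the series, on what has been measured and on what is new or still open speak of the compounds shown alone.

Compound 1 `COc1ccc(-c2cnc(NC(=O)c3cccnc3)n2C)cc1` was examined in a toxicity assay on THP-1 cells (Homo sapiens) for inhibition; a higher number here means that more compound is tolerated, a lower number that less compound is tolerated. In this assay compound 1 gives > 100000 nM, which is a limit of the assay and not a number, so compound 1 stands only at a limit (the limit of > 100000 nM in this assay, at which 1 of the 2 values shown sits). Compound 2 `Cn1c(-c2ccc([N+](=O)[O-])cc2)cnc1NC(=O)c1ccc(F)cc1` was examined in the same way. In this assay compound 2 gives > 50000 nM, again only a limit. Compound 3 `COc1ccc(-c2cnc(NC(=O)c3cccc(F)c3)n2C)cc1` is still unmeasured. It differs from compound 1 by 3-fluorophenyl in place of pyridin-3-yl on a carbonyl carbon. Within the data shown here, no measured step is available to size this change. The step is expected to be a number no higher from compound 1 to compound 3 (the limit leaves the size open), nothing beyond the scatter. Compound 3 is therefore estimated at 100000 nM, between 30000 nM and 300000 nM.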

Compound 3, half-maximal cytotoxic concentration: > 100000 nM
Compound 3 gave a limit, no number (the forecaster's own chance of this, stated with the estimate: 85%); the middle value sits exactly at the limit.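

Compound 1 and compound 3 both stand only at a limit in this assay, and no step can be read between them. The compounds shown leave open whether 3-fluorophenyl in place of pyridin-3-yl changes tolerance at all.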